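The compounds below may be only part of what the source reports. "The series", "measured", "known", "first", "only" and "open" are said of these compounds alone.

In a physicochemical assay for solubility, read by nephelometry, in phosphate buffer, measured as kinetic solubility, at pH 2 (on this read-out higher numbers stand for higher solubility and lower numbers for lower solubility), compound 1 `O=C(Nc1ccc(F)c(-c2nc3ncccc3o2)c1)c1ccoc1` gives 12.5 ug/mL and compound 2 `Cc1ccc(NC(=O)c2ccoc2)cc1-c1nc2ncccc2o1` gives 12.5 ug/mL, so compound 2 stands level with compound 1. Compound 3 `Cc1ccc(NC(=O)c2occc2C)cc1-c1nc2ncccc2o1` keeps the rest of compound 2 and changes the group on the carbonyl carbon: 3-methylfuran-2-yl in place of furan-3-yl on a carbonyl carbon. In words, this is 3-methylfuran-2-yl in place of furan-3-yl on a carbonyl carbon. Within the data shown here, the only measured step, no change at the digits printed from compound 1 to compound 2 (within the scatter), is methyl in place of fluoro on an aromatic carbon, elsewhere in the molecule, and so bears on this change only indirectly. Among the measured compounds shown here, no measured step alters the group on the carbonyl carbon, so the data indicate no direction. The expected change is therefore none beyond the scatter, with a wide margin: the estimated step is a 1.1-fold lower number from compound 2 to compound 3 (0.06 log units; within the scatter). For compound 3 the expected value is 11 ug/mL, with an estimated range of 4 ug/mL to 30 ug/mL.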

Compound 3, solubility: 1.6 ug/mL
For compound 3 the middle estimate is 6.9-fold (0.84 log units) above the measured one, and the stated range ends above it.
By their numbers in this assay, from the lowest: compound 3; then compounds 1 and 2 (each within the scatter of the next).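

In this assay, among these compounds, the group on the carbonyl carbon is the first place where a single change moves the read-out beyond the scatter: 3-methylfuran-2-yl in place of furan-3-yl gives a 7.8-fold lower number from compound 2 to compound 3 (0.89 log units; beyond the scatter), whereas methyl in place of fluoro on an aromatic carbon gave no change at the digits printed from compound 1 to compound 2 (within the scatter), so the series does not respond alike to every single change. Among the compounds shown here, nothing measured so far accounts for this step.

Still open, as far as these compounds go, is whether the lower number goes with the added methyl or with the change from furan-3-yl to a furan-2-yl attachment, a question that plain furan-2-yl on the same carbonyl carbon would separate. Also open, from the compounds shown here alone, is how a furan carrying an aminomethyl group or a carboxylic acid would read at this place in this assay.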